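A Second Methyl on a Shared Core

The source may report more compounds than this note shows. Statements on the series, on what has been measured and on what is new or still open speak of the compounds shown alone.

Of the compounds shown here, three of one family have been tested in a functional assay on the whole organism with Rattus norvegicus as the target, read by paw edema, with a stated time of 3 h, at a dose of 100 mg/kg by the oral route; a lower number here means less inhibition, a higher number more inhibition at the dose given (going by the name of the read-out). Compound 1 `Cc1ccc2[nH]c(-c3cccc(C)n3)nc2c1` gives 42%. Compound 2 `CCc1ccc(-c2nc3cc(Cl)ccc3[nH]2)nc1` gives -2%. Compound 3 `Cc1ccc(-c2nc3ccccc3[nH]2)nc1C` gives 37%. Among these three numbers, compound 3 stands second highest: its nearest neighbour is compound 1, whose number lies higher by an amount within the usual scatter, and its furthest is compound 2, whose number lies lower by an amount well beyond the scatter.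

Compound 4 `Cc1ccc2[nH]c(-c3ccc(C)c(C)n3)nc2c1` has not yet been measured in this assay. It differs from compound 3 in one place: methyl in place of hydrogen on an aromatic carbon. Within the data shown here, no pair of measured compounds differs by just this change, so the expectation rests on the spread seen so far. The step of a number 3 percentage points higher from compound 3 to compound 4 (within the scatter) is expected to stay within the scatter. Compound 4 is estimated to give about 40%, between 22% and 56%.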

Compound 4, a percentage reported as inhibition, in the whole organism at one dose (the size of the read-out at that dose, not a potency): -19%
Estimate against measurement, compound 4: 59 percentage points above, outside the stated range (below it).
By their numbers in this assay, from the lowest: compound 4; then compound 2; then compounds 3 and 1 (each within the scatter of the next).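

In this assay, a single methyl in place of hydrogen on an aromatic carbon is enough to bring a number 56 percentage points lower from compound 3 to compound 4 (beyond the scatter), and the same swap at a different aromatic carbon of the shared core brings a number 61 percentage points lower from compound 1 to compound 4 (beyond the scatter). So in this family, the smallest of additions to either compound can take away all the inhibition seen at this dose, which the earlier compounds gave no sign of. Nothing available here bears on why the number falls.

On these data alone, whether a methoxy group or an amine on that same aromatic carbon would act as the methyl does remains open. Also open, as far as these compounds go, is whether hydrogen at one of these two carbons alone is what the inhibition requires.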